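Trading 6-aminopyridin-3-yl for 3-amino-1H-indazol-6-yl

This account rests on a few compounds, and the source may have more. Where it says the series, first, only, none or still open, it means among the compounds named here.

Within the data shown here, in a functional assay on K562 cells (Homo sapiens) for inhibition, read by MTT assay, with a stated time of 48 h (a higher number here means a weaker inhibitor, a lower number a stronger inhibitor), compound 1 `CC(C)(C)OC(=O)N1C[C@@H](n2cc(-c3ccc(N)nc3)nn2)C[C@H]1C(=O)Nc1ccc(Cl)c(C(F)(F)F)c1` gives 4710 nM, the lower of the two numbers so far, while compound 2 `Nc1ccc(-c2cn([C@@H]3CN[C@H](C(=O)Nc4ccc(Cl)c(C(F)(F)F)c4)C3)nn2)cn1` gives 10400 nM. Compound 3 `CC(C)(C)OC(=O)N1C[C@@H](n2cc(-c3ccc4c(N)n[nH]c4c3)nn2)C[C@H]1C(=O)Nc1ccc(Cl)c(C(F)(F)F)c1` keeps the core of compound 1 but carries 3-amino-1H-indazol-6-yl in place of 6-aminopyridin-3-yl on an aromatic carbon. Among the measured compounds shown here, the only measured step, a 2.2-fold higher number from compound 1 to compound 2 (0.34 log units; beyond the scatter), is modest and concerns the loss of tert-butoxycarbonyl, not this exchange. With no measured guide, no shift beyond the scatter is expected: the expected step is a 1.3-fold lower number from compound 1 to compound 3 (0.13 log units; within the scatter). For compound 3 the estimated value is 3500 nM, with an expected range of 900 nM to 12000 nM.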

Compound 3, half-maximal inhibitory concentration: 10500 nM
For compound 3 the middle estimate is 3.0-fold (0.48 log units) below the measured one, within the range that was stated.
By their numbers in this assay, from the lowest: compound 1; then compounds 2 and 3 (each within the scatter of the next).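

In this assay, among these compounds, the exchange of 6-aminopyridin-3-yl for 3-amino-1H-indazol-6-yl brings a 2.2-fold higher number from compound 1 to compound 3 (0.35 log units; beyond the scatter) and gives the first measured change at this aromatic carbon, where the earlier step concerned only the tert-butoxycarbonyl on the ring amine. Among these two groups, 6-aminopyridin-3-yl therefore gives the stronger inhibition on the core of compound 1. Nothing available bears on the reason for this modest loss.

From the compounds shown here alone, it remains open whether the exchange has the same effect without the tert-butoxycarbonyl. Also open, going by these compounds, is how a simple phenyl or a carboxylic acid would fare on this aromatic carbon.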